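This account rests on a few compounds, and the source may have more. Where it says the series, first, only, none or still open, it means among the compounds named here.

Measured in a functional assay on HeLa S3 cells (Homo sapiens) for antiproliferative activity, read by XTT assay, with a stated time of 72 h; on this read-out higher numbers stand for weaker inhibition and lower numbers for stronger inhibition:
- Compound 1 `Cc1ncnc2c1c(-c1cc3ccccc3o1)cn2[C@@H]1O[C@H](CO)[C@@H](O)[C@H]1O`: > 20000 nM, a limit of the assay
- Compound 2 `O=c1[nH]cnc2c1c(-c1ccccc1)cn2[C@@H]1O[C@H](CO)[C@@H](O)[C@H]1O`: > 20000 nM, a limit of the assay

Compound 2 has no number in this assay, only the limit > 20000 nM. The same holds for the whole measured set: the limit of > 20000 nM in this assay, at which 2 of the 2 values shown sit. Going by the values given here, no step between measured compounds is available, so the position of compound 2 beyond that limit is unknown.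

The next compound is compound 3 `O=c1[nH]cnc2c1c(-c1cc3ccccc3o1)cn2[C@@H]1O[C@H](CO)[C@@H](O)[C@H]1O`, which carries 1-benzofuran-2-yl in place of phenyl on an aromatic carbon of the shared core: 1-benzofuran-2-yl in place of phenyl on an aromatic carbon. The rest of compound 2 stays as it is.

Among the compounds with values here, no measured step guides the expectation in this assay. No step beyond the usual scatter is expected, and any shift would have to be towards stronger inhibition to show up as a number at all. This expectation rests on the limit > 20000 nM of compound 2. The expected size of the change is a number no higher from compound 2 to compound 3 (the limit leaves the size open). Compound 3 is estimated at 20000 nM, with an expected range of 8000 nM to 40000 nM, and a further limit is the most likely report.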

Compound 3, half-maximal inhibitory concentration: > 20000 nM
Compound 3 ended at the assay's limit (the forecaster's own chance of this, stated with the estimate: 85%); the middle value sits exactly at the limit.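

No step can be read from compound 2 to compound 3 in this assay: both results are limits of the assay, not numbers. The set holds no number so far: the limit of > 20000 nM in this assay, at which 3 of the 3 values shown sit.

The compounds shown leave open how far each lies beyond that limit, and whether 1-benzofuran-2-yl in place of phenyl changes anything.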